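The source may report more compounds than this note shows. Statements on the series, on what has been measured and on what is new or still open speak of the compounds shown alone.

Compound 1, `Nc1ccccc1NC(=O)c1ccc(CSc2ccc(Br)cc2)cc1`: 25.3%
Compound 2, `Nc1ccccc1NC(=O)/C=C/c1ccc(CSc2ccc(F)cc2)cc1`: 15.4%
Compound 3, `COc1ccc(SCc2ccc(C(=O)Nc3ccccc3N)cc2)cc1`: 80.1%

In a functional assay on SMMC-7721 cells (Homo sapiens) for inhibition, read by CCK-8 assay, with a stated time of 72 h, tested at 8 uM (on this read-out higher numbers stand for more inhibition of growth at the one concentration tested and lower numbers for less inhibition of growth), compound 2 stands at the low end of the three numbers; compound 1 lies within the scatter of it, while compound 3 lies far beyond it. Compound 4, `Nc1ccccc1NC(=O)/C=C/c1ccc(CSc2cccc3ccccc23)cc1`, differs from compound 2 by naphthalen-1-yl in place of 4-fluorophenyl on a sulfur. Going by the values given here, the single measured step, a number 54.8 percentage points higher from compound 1 to compound 3 (beyond the scatter), concerns another group at another place and so bears only loosely on this change; no measured pair shows what exchanging the whole ring on the sulfur does. A step of uncertain size, more likely upward than downward, is therefore expected in this assay. Compound 4 is estimated at 30%, between 5% and 60%. This estimate means an expected step of a number 14.6 percentage points higher from compound 2 to compound 4 (beyond the scatter).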

Compound 4, percent growth inhibition at one concentration: 18.3%
Compound 4: the middle estimate sits 11.7 percentage points above what was measured; the range from low to high includes it.
By their numbers in this assay, from the lowest: compounds 2, 4 and 1 (each within the scatter of the next); then compound 3.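

In this assay the exchange of the whole ring on the sulfur gives a number 2.9 percentage points higher from compound 2 to compound 4 (within the scatter) and so separates naphthalen-1-yl from 4-fluorophenyl at this place by no more than the scatter. On this one pair, a second six-membered aromatic ring on the sulfur leaves the read-out unresolved from that of the single ring. Nothing available here bears on the reason for this result. On these data alone, it remains open whether an amine or a carboxylic acid on the ring at this sulfur would shift the number, and whether the methoxy-for-bromo step would carry over to the core of compound 2.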